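This account rests on a few compounds, and the source may have more. Where it says the series, first, only, none or still open, it means among the compounds named here.

Measured compounds and their values:

Compound 1, `O=C(Nc1ccc(OCc2nc3ccccc3s2)cc1)Nc1ccc(Cl)c(Cl)c1`, gives 570 nM in an assay on isolated protein for inhibition of Polyunsaturated fatty acid 5-lipoxygenase (Homo sapiens), read by HPLC, with a stated time of 10 min; a lower number here means a stronger inhibitor, a higher number a weaker inhibitor.
Compound 2, `O=C(Nc1ccc(OCc2nc3ccccc3s2)cc1)Nc1ccccc1Cl`, gives 360 nM in this assay.

Among the compounds with values here, compound 2 holds the lowest of the two numbers in this assay, but its only neighbour, compound 1, sits within the scatter of it, so the two cannot be ordered. The change to compound 3, `O=C(Nc1ccc(Cl)cc1)Nc1ccc(OCc2nc3ccccc3s2)cc1`, is 4-chlorophenyl in place of 2-chlorophenyl on an amide-type nitrogen. Within the data shown here, only one measured step bears on a chlorophenyl rearrangement on this amide-type nitrogen, a 1.6-fold lower number from compound 1 to compound 2 (0.20 log units; within the scatter), and it stayed within the scatter. Compound 3 is therefore expected to show a 1.3-fold higher number from compound 2 to compound 3 (0.10 log units; within the scatter), which is no step beyond the scatter in either direction. On that basis compound 3 is estimated at 450 nM in this assay, with a range from 180 nM to 1100 nM.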

Compound 3, half-maximal inhibitory concentration: 1010 nM
Estimate against measurement, compound 3: 2.2-fold (0.35 log units) below, and the stated range covers the measured number.
By their numbers in this assay, from the lowest: compounds 2, 1 and 3 (each within the scatter of the next, the first and the last beyond it).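

In this assay, within the data shown here, the placement of the chlorine on the phenyl ring carried by this amide-type nitrogen now makes a measurable difference, since 4-chlorophenyl in place of 2-chlorophenyl gives the first step beyond the scatter, though a modest one (a 2.8-fold higher number from compound 2 to compound 3 (0.45 log units; beyond the scatter)). Compound 1 and compound 3 cannot be ordered (a 1.8-fold higher number from compound 1 to compound 3 (0.25 log units; within the scatter)), so hydrogen in place of chloro on that aromatic carbon shows no readable effect. Nothing given here accounts for the difference between the two chlorine placements.

As far as these compounds go, whether the same difference between placements appears with methyl or methoxy in place of chloro remains open. So does the outcome for plain phenyl, or for a phenyl ring bearing an amine or a carboxylic acid, on this nitrogen.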